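Solubility notes: benzothiazole in place of piperidine on the core

This account rests on a few compounds, and the source may have more. Where it says the series, first, only, none or still open, it means among the compounds named here.

Compound 2 `COCC1CCN(c2nccnc2OC2CN(c3ccc4ccccc4n3)C2)CC1` gives 53000 nM in a physicochemical assay for solubility, in phosphate buffer, at pH 7.4 (a higher number here means a more soluble compound, a lower number a less soluble compound), the highest of the three numbers in hand, though neither neighbour is separated from it beyond the scatter: compound 1 `OC1CN(c2nccnc2OC2CN(c3ccc4ccccc4n3)C2)C1` gives 41000 nM and compound 3 `OCc1cccc(-c2nccnc2OC2CN(c3ccc4ccccc4n3)C2)c1` gives 29000 nM. The steps are a 1.3-fold higher number from compound 1 to compound 2 (0.11 log units; within the scatter) and a 1.8-fold lower number from compound 2 to compound 3 (0.26 log units; within the scatter), with a 1.4-fold lower number from compound 1 to compound 3 (0.15 log units; within the scatter) between the other pair.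

Compound 4 `c1ccc2nc(N3CC(Oc4nccnc4-c4ccc5scnc5c4)C3)ccc2c1` differs from compound 2 by 1,3-benzothiazol-5-yl in place of 4-(methoxymethyl)piperidin-1-yl on an aromatic carbon. The step that bears most on this is a 1.8-fold lower number from compound 2 to compound 3 (0.26 log units; within the scatter), where a saturated ring amine likewise gave way to a group built on aromatic rings, with a 1.4-fold lower number from compound 1 to compound 3 (0.15 log units; within the scatter) pointing the same way; both stayed within the scatter. A lower number is therefore expected for compound 4, likely of similar size, with the edge of the scatter in reach because a 1.8-fold lower number from compound 2 to compound 3 (0.26 log units; within the scatter) already sat near it. The expected step is a 2.9-fold lower number from compound 2 to compound 4 (0.47 log units; beyond the scatter). Compound 4 is estimated at 18000 nM, with a range from 6000 nM to 45000 nM.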

Compound 4, solubility: < 1000 nM
Compound 4: only a limit was reported (the forecaster's own chance of this, stated with the estimate: 5%); middle value at least 18-fold (1.25 log units) away from the limit.
By their numbers in this assay, from the lowest: compounds 3, 1 and 2 (each within the scatter of the next). At a limit, below all of these: compound 4.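

Compound 4 stands at a limit of this assay, not at a number: the limit of < 1000 nM in this assay, at which 1 of the 4 values shown sits.

On this aromatic carbon, next to the ring nitrogen, 3-hydroxyazetidin-1-yl, 4-(methoxymethyl)piperidin-1-yl and 3-(hydroxymethyl)phenyl had all stayed within the scatter of one another, whereas 1,3-benzothiazol-5-yl leaves that band, with an at least 53-fold lower number from compound 2 to compound 4 (1.72 log units; beyond the scatter) and an at least 41-fold lower number from compound 1 to compound 4 (1.61 log units; beyond the scatter). Compound 3 also carries an aromatic ring at this carbon, yet an at least 29-fold lower number from compound 3 to compound 4 (1.46 log units; beyond the scatter) is large as well, so an aromatic ring here does not by itself go with a low reading.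

The compounds shown leave open whether the drop goes with the two-ring group as a whole or with its sulfur. Nor do they show whether a plain phenyl, or a hydroxymethyl or an amine on the 1,3-benzothiazol-5-yl, would read closer to compound 3.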